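The source may hold more compounds than are shown below. What is called first, only, known or untested is meant among the compounds shown, and "the series" means these compounds.

Working notes on a small urea series sharing one core.

Three compounds have numbers in an assay on isolated protein for inhibition of serine/threonine-protein kinase TNNI3K (Homo sapiens); a higher number here means a weaker inhibitor, a lower number a stronger inhibitor. Compound 1 `CNc1cc(Oc2ccc(NC(=O)Nc3cccc(CF)c3)cc2)ncn1` gives 400 nM. Compound 2 `CNc1cc(Oc2ccc(NC(=O)Nc3cccc(C(F)(F)F)c3)c(F)c2)ncn1` gives 63 nM. Compound 3 `C[C@H](O)CNc1cc(Oc2ccc(NC(=O)Nc3cccc(C(F)(F)F)c3)cc2)ncn1` gives 32 nM. Among these three, compound 1 carries the highest number, and both compound 2 and compound 3 sit below it by more than the usual scatter, so compound 1 is the weakest of the three measured entries. For the measured compounds named here, no pair among them differs in a single place, so no individual step can be read off; compound 2 and compound 3 each differ from compound 1 at more than one point.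

The next entry, compound 4 `CNc1cc(Oc2ccc(NC(=O)Nc3cccc(C)c3)cc2)ncn1`, is compound 1 with one change: hydrogen in place of fluoro on a saturated chain carbon bound to an aromatic carbon. Read one bond further out, fluoromethyl becomes methyl, so 3-(fluoromethyl)phenyl becomes 3-methylphenyl on the urea.

Nothing measured here speaks directly to this exchange. Going by the values given here, with no comparable step on record, the working expectation is a step of no change at the digits printed from compound 1 to compound 4 (within the scatter) in this assay, that is, no change beyond the scatter in either direction. Compound 4 is therefore estimated at 400 nM, with a range from 150 nM to 1100 nM.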

Compound 4, half-maximal inhibitory concentration: 1260 nM
Compound 4: middle estimate off by 3.2-fold (0.50 log units), on the low side; the whole stated range lies below it.
By their numbers in this assay, from the lowest: compounds 3 and 2 (each within the scatter of the next); then compound 1; then compound 4.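

In this assay, for the compounds shown here, hydrogen in place of fluoro on a saturated chain carbon bound to an aromatic carbon gives a 3.2-fold higher number from compound 1 to compound 4 (0.50 log units; beyond the scatter) and is the first step that can be read at a single place. It shows that this position responds to the exchange of fluoromethyl for methyl: removing one fluorine moves the number up beyond the scatter, so 3-(fluoromethyl)phenyl on the urea gives the stronger inhibitor of this pair. Nothing on hand accounts for the size or direction of this step.

Compound 2 and compound 3 carry trifluoromethyl at this place but also differ from compound 1 and compound 4 elsewhere, so their steps to those two compounds cannot be read, and the effect of adding further fluorines to this carbon stays unresolved. Also open, from the compounds shown here alone, are how difluoromethyl, chloro, methoxy or a longer chain such as ethyl would behave here, and whether the fluoro to hydrogen exchange gives a similar step on the side chain of compound 3.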